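Swapping the aryl amide halogen: chloro to fluoro

A few compounds are considered here, and "the series" means these few. Any claim that something is new, unique, unknown or untested is made for them only; others in the source may bear on it.

Going by the values given here, compound 2 `CC(C)OC(=O)C1CN(C(=O)c2ccc(Cl)cc2)CC(C)(C)c2cc(C#N)[nH]c21` stands highest of the two numbers known in an assay on HEK293 cells for agonist activity at Bile acid receptor (Homo sapiens), read by a luciferase reporter (on this read-out lower numbers stand for smaller maximal responses and higher numbers for larger maximal responses), giving 115%; the nearest value is that of compound 1 `CC(C)OC(=O)C1CN(C(=O)c2cccc(Cl)c2)CC(C)(C)c2cc(C#N)[nH]c21`, which gives 103%. Among the compounds with values here, the one measured step, a number 12 percentage points higher from compound 1 to compound 2 (beyond the scatter), bears only partly on the change to compound 3 `CC(C)OC(=O)C1CN(C(=O)c2cccc(F)c2)CC(C)(C)c2cc(C#N)[nH]c21`, which is 3-fluorophenyl in place of 4-chlorophenyl on a carbonyl carbon. Because a number 12 percentage points higher from compound 1 to compound 2 (beyond the scatter) was modest and the new change undoes the 4-chlorophenyl arrangement while also exchanging the halogen, the expected result for compound 3 is a modest fall, roughly back toward compound 1, with a number 13 percentage points lower from compound 2 to compound 3 (beyond the scatter). Compound 3 is thus estimated at 102%, between 86% and 118%.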

Compound 3, largest response reached (reported as efficacy), in percent of the reference or control that the assay uses in the Bile acid receptor assay: 84%
For compound 3 the middle estimate is 18 percentage points above the measured one; measured number below the stated range.
By their numbers in the Bile acid receptor assay, from the lowest: compound 3; then compound 1; then compound 2.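

In the Bile acid receptor assay, fluoro in place of chloro on an aromatic carbon gives a number 19 percentage points lower from compound 1 to compound 3 (beyond the scatter), so at this place the identity of the halogen counts as well as its arrangement on the ring, and the full change gives a number 31 percentage points lower from compound 2 to compound 3 (beyond the scatter). In a physicochemical assay for solubility, at pH 7.4 (on this read-out higher numbers stand for higher solubility and lower numbers for lower solubility), compound 2 gives 5 ug/mL. In the physicochemical assay compound 3 gives > 100 ug/mL, which is a limit of the assay. Open, on these data alone, is how a 4-fluorophenyl group, or a methoxy group in place of the halogen, would fare in both read-outs, and so how much of the gap between compound 2 and compound 3 belongs to the halogen and how much to where it sits.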